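This account rests on a few compounds, and the source may have more. Where it says the series, first, only, none or still open, it means among the compounds named here.

Two compounds of the series have numbers in a functional assay on HeLa cells (Homo sapiens) for inhibition, read by MTT assay, with a stated time of 48 h; a higher number here means a weaker inhibitor, a lower number a stronger inhibitor. Compound 1 `COc1ccc2c(=O)c(/C=C/C(=O)Nc3cccc(Cl)c3)coc2c1` gives 11900 nM, and compound 2 `COc1ccc2c(=O)c(/C=C/C(=O)NCc3cccc(F)c3)coc2c1` gives 17600 nM. For the measured compounds named here, the only step between them, a 1.5-fold higher number from compound 1 to compound 2 (0.17 log units; within the scatter), alters the whole group on the amide-type nitrogen and does not separate the two numbers. Compound 1 therefore holds the lowest of the two numbers, with compound 2 the nearest, though the gap does not rank them.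

Compound 3 `COc1ccc2c(=O)c(/C=C/C(=O)Nc3cc(C)ccc3C)coc2c1` differs from compound 1 in one place: 2,5-dimethylphenyl in place of 3-chlorophenyl on an amide-type nitrogen. Going by the values given here, no measured step replaces one ring substituent set by another on the amide-type nitrogen, so the step from compound 1 to compound 2 is the sole point of reference, and it lies within the scatter. The step of a 1.1-fold higher number from compound 1 to compound 3 (0.04 log units; within the scatter) is accordingly expected to stay within the usual scatter, with no settled direction. Compound 3 is estimated at 13000 nM in this assay, with a range from 4000 nM to 40000 nM that allows for the absence of any directly comparable step.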

Compound 3, half-maximal inhibitory concentration: 58400 nM
Compound 3: middle estimate off by 4.5-fold (0.65 log units), on the low side; measured number above the stated range.
By their numbers in this assay, from the lowest: compounds 1 and 2 (each within the scatter of the next); then compound 3.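

In this assay the group on the amide-type nitrogen does separate compounds: 2,5-dimethylphenyl gives a 4.9-fold higher number from compound 1 to compound 3 (0.69 log units; beyond the scatter) and also a 3.3-fold higher number from compound 2 to compound 3 (0.52 log units; beyond the scatter) with both steps beyond the scatter, unlike the earlier step at this place. Compound 3 therefore carries the weakest number of the three, and a phenyl ring on this nitrogen does not by itself keep the number low, since compound 1 and compound 3 both hold one. No measurement at hand accounts for this rise.

Entry of both methyl groups and loss of the chlorine come in a single step, so the compounds shown do not tell whether one methyl group alone or the loss of chlorine carries the rise. As far as these compounds go, how the number responds to an amine, a carboxylic acid or a longer chain on this nitrogen also remains open.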